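The compounds below may be only part of what the source reports. "The series", "measured", "known", "first", "only" and "open" are said of these compounds alone.

Compound 1, `CCCCS(=O)(=O)c1sc2nc(-c3nccs3)cc(-c3cnc(C)n3C)c2c1N`: 32 nM
Compound 2, `CCCC[S+]([O-])c1sc2nc(-c3nccs3)cc(-c3ccc(CNS(C)(=O)=O)cc3)c2c1N`: 4.6 nM
Compound 3, `Nc1c([S+]([O-])CCCF)sc2nc(-c3cccs3)cc(-c3ccccc3)c12`: 6.1 nM

All three were tested in an assay for inhibition of 15-hydroxyprostaglandin dehydrogenase [NAD(+)] (Homo sapiens), read by fluorescence, with a stated time of 15 min, in the presence of a further agent that is not named here; on this read-out higher numbers stand for weaker inhibition and lower numbers for stronger inhibition. Compound 2 has the lowest number of the three, but compound 3 sits within the usual scatter of it, so the two cannot be told apart; only compound 1 stands clearly away from compound 2, beyond the scatter. Compound 4, `CCCC[S+]([O-])c1sc2nc(-c3nccs3)cc(-c3ccc(COC(=O)NCC)cc3)c2c1N`, has not yet been measured. It differs from compound 2 in one place: (ethylcarbamoyl)oxy in place of methanesulfonamido on a saturated chain carbon bound to an aromatic carbon. Among the compounds with values here, no measured pair shows this same change, so there is nothing to calibrate the step against. A small step in this assay toward a higher number is expected, a 1.7-fold higher number from compound 2 to compound 4 (0.24 log units; within the scatter), not clearly beyond the scatter. Compound 4 is estimated at 8 nM, with a range from 2.5 nM to 25 nM.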

Compound 4, half-maximal inhibitory concentration: 3.4 nM
Compound 4: middle estimate off by 2.4-fold (0.37 log units), on the high side, and the stated range covers the measured number.
By their numbers in this assay, from the lowest: compounds 4, 2 and 3 (each within the scatter of the next); then compound 1.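

In this assay the exchange of methanesulfonamido for (ethylcarbamoyl)oxy on a saturated chain carbon bound to an aromatic carbon gives a 1.4-fold lower number from compound 2 to compound 4 (0.13 log units; within the scatter) and so leaves the two compounds indistinguishable. This position therefore accepts both groups in this pair, and the sulfur of methanesulfonamido is not required to keep the number in this range. Nothing available explains why the two groups match.

Still open, as far as these compounds go, is how an amine or a carboxylic acid would fare on that same carbon. Also open, from the compounds shown here alone, is whether a longer chain in place of the ethyl in (ethylcarbamoyl)oxy would be accepted equally well.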